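Removing the Propoxycarbonyl Group: Expected Effect on Cytotoxicity

The source may hold more compounds than are shown below. What is called first, only, known or untested is meant among the compounds shown, and "the series" means these compounds.

Measured compounds:
compound 1 `CCCOC(=O)c1ccc(OCCCCCn2ccc(=O)[nH]c2=O)cc1`: > 100000 nM
compound 2 `O=c1ccn(CCCOc2ccc(Br)cc2)c(=O)[nH]1`: "not determined" (no result reported)

Both compounds carry the same core joined by a chain to a six-membered carbon ring. In an ADME assay on HEL cells (Homo sapiens) for cytotoxicity (on this read-out lower numbers stand for higher toxicity in this test and higher numbers for lower toxicity in this test), compound 1 gives > 100000 nM; this is a limit of the assay and not a number. For compound 2 the result in this assay is "not determined" (no result reported). Compound 1 therefore stands at the limit of > 100000 nM in this assay, at which 1 of the 2 values shown sits, and no single numerical value is available for comparison.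

Compound 3 `O=c1ccn(CCCCCOc2ccccc2)c(=O)[nH]1` has not yet been measured. It differs from compound 1 in one place: hydrogen in place of propoxycarbonyl on an aromatic carbon. With only a limit to start from, no step beyond the usual scatter is expected in this assay, in either direction. The expected step is a number no higher from compound 1 to compound 3 (the limit leaves the size open). For compound 3 the estimated value in this assay is 100000 nM, expected to fall between 30000 nM and 300000 nM, most likely again reported only as a limit.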

Compound 3, half-maximal cytotoxic concentration: > 100000 nM
Compound 3: a limit, no number (the forecaster's own chance of this, stated with the estimate: 80%); the middle value sits exactly at the limit.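

Compound 1 and compound 3 both give a limit of the assay and not a number, so no step between them can be read: the limit of > 100000 nM in this assay, at which 2 of the 3 values shown sit.

The compounds shown leave open whether hydrogen in place of propoxycarbonyl changes the result in this assay at all, and at what concentration either compound would harm these cells.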